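The source may hold more compounds than are shown below. What is called first, only, known or untested is meant among the compounds shown, and "the series" means these compounds.

Of the compounds shown here, two with a shared core have been measured in a functional assay on Vero cells (Chlorocebus sabaeus) for inhibition; on this read-out higher numbers stand for weaker inhibition and lower numbers for stronger inhibition. Compound 1 (`COc1cc(/C=C/C(=O)c2cccc(NC(=O)c3cccs3)c2)ccc1O`), with thiophen-2-yl on the carbonyl carbon, gives 3.98 ug/mL. Compound 2 (`COc1cc(/C=C/C(=O)c2cccc(NC(=O)c3ccc(Cl)cc3Cl)c2)ccc1O`), with 2,4-dichlorophenyl at that place, gives 27.2 ug/mL, the higher of the two numbers and thus the weaker inhibition. Among the compounds with values here, the only measured step is a 6.8-fold higher number from compound 1 to compound 2 (0.83 log units; beyond the scatter), and it replaces thiophen-2-yl with 2,4-dichlorophenyl.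

Compound 3 (`CCCC(=O)Nc1cccc(C(=O)/C=C/c2ccc(O)c(OC)c2)c1`) has not yet been measured. Its difference from compound 2 is propyl in place of 2,4-dichlorophenyl on a carbonyl carbon, which puts propyl in place of 2,4-dichlorophenyl on a carbonyl carbon. The step of a 6.8-fold higher number from compound 1 to compound 2 (0.83 log units; beyond the scatter) bears on this change only in part: it shows what arriving at 2,4-dichlorophenyl did, whereas here that group leaves. Within the data shown here, no measured compound carries propyl, so the size of the move remains uncertain. A move to a lower number, somewhat smaller than that measured step, is therefore expected. For compound 3 the estimate is 10 ug/mL, with an expected range from 3 ug/mL to 35 ug/mL. This estimate means an expected 2.7-fold lower number from compound 2 to compound 3 (0.43 log units; beyond the scatter).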

Compound 3, half-maximal inhibitory concentration: 2.04 ug/mL
Estimate against measurement, compound 3: 4.9-fold (0.69 log units) above; the whole stated range lies above it.
By their numbers in this assay, from the lowest: compounds 3 and 1 (each within the scatter of the next); then compound 2.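

In this assay, within the data shown here, putting propyl on the carbonyl carbon in place of 2,4-dichlorophenyl gives a 13-fold lower number from compound 2 to compound 3 (1.12 log units; beyond the scatter), so a ring at this place is not needed for a low number, and the earlier compounds could not show this because both carried one. The comparison with the thiophen-2-yl compound gives a 2.0-fold lower number from compound 1 to compound 3 (0.29 log units; within the scatter), so an open chain and this five-membered-ring group cannot be told apart here, and among the three compounds only 2,4-dichlorophenyl stands out, with the high number. Nothing available explains why this group behaves differently from the other two, so the data record the difference without accounting for it.

On these data alone, what remains open is whether the high number of compound 2 belongs to the phenyl ring itself or to its two chlorine atoms, a question that plain phenyl or a phenyl carrying a single chlorine would address. As far as these compounds go, it is also open how far an open chain can go at this place, which a longer chain such as hexyl, a branched chain such as isopropyl, or a chain ending in an amine would test.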